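Shortening the Ether Alkyl on an Aryloxy Imidazoline Series

The source may hold more compounds than are shown below. What is called first, only, known or untested is meant among the compounds shown, and "the series" means these compounds.

Three compounds share a core in which an imidazoline is joined through a one-carbon branch and an oxygen to an aromatic ring bearing a second substituent. Compound 1 `CCc1ccccc1OC(C)C1=NCCN1` gives 288 nM in an assay on CHO cells for displacement of a labelled ligand from Alpha-2C adrenergic receptor (Homo sapiens); on this read-out lower numbers stand for stronger inhibition and higher numbers for weaker inhibition. Compound 2 `C=C(C)c1ccccc1OC(C)C1=NCCN1` gives 603 nM in this assay, and compound 3 `CC(C)Oc1ccccc1OC(C)C1=NCCN1` gives 398 nM. Among the steps between them, a 2.1-fold higher number from compound 1 to compound 2 (0.32 log units; beyond the scatter) is the only one beyond the scatter; a 1.4-fold higher number from compound 1 to compound 3 (0.14 log units; within the scatter) and a 1.5-fold lower number from compound 2 to compound 3 (0.18 log units; within the scatter) are both within it, so compound 3 sits within the scatter of both neighbours.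

Compound 4 `COc1ccccc1OC(C)C1=NCCN1` differs from compound 3 in one place: methyl in place of isopropyl on an oxygen on an aromatic ring. Going by the values given here, none of the measured steps touches the alkyl on this oxygen; the measured steps replace the whole aromatic substituent, so they give no direct guide to the size of this change. With the three aromatic substituents spanning only a modest range, the expectation for this assay is a step near or within the scatter, with no clear direction.

Compound 4 is therefore estimated at 250 nM, with a range from 90 nM to 700 nM. This estimate means a step of a 1.6-fold lower number from compound 3 to compound 4 (0.20 log units; within the scatter) from compound 3 to compound 4 is expected.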

Compound 4, inhibition constant: 832 nM
Compound 4: middle estimate off by 3.3-fold (0.52 log units), on the low side; measured number outside the range, above it.
By their numbers in this assay, from the lowest: compounds 1, 3, 2 and 4 (each within the scatter of the next, the first and the last beyond it).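

In this assay, going by these compounds alone, the alkyl on this oxygen proves to matter: isopropoxy to methoxy gives a 2.1-fold higher number from compound 3 to compound 4 (0.32 log units; beyond the scatter) and so moves the number beyond the scatter, something the earlier steps, which replaced the whole aromatic substituent, could not show. Methoxy also separates from ethyl on the aromatic carbon, with a 2.9-fold higher number from compound 1 to compound 4 (0.46 log units; beyond the scatter) as a larger step toward weaker inhibition, whereas the comparison with 1-methylethenyl gives a 1.4-fold higher number from compound 2 to compound 4 (0.14 log units; within the scatter) and leaves those two substituents unresolved. The data shown offer no account of why the shorter alkyl on this oxygen goes with the higher number.

With only isopropyl and methyl shown on this oxygen, it remains open whether ethoxy would fall between them or whether the change would appear only once the branched isopropyl is lost. On these data alone, it is also open whether a longer chain such as n-butoxy, or a ring such as cyclopropylmethoxy, would hold the number near that of compound 3 or carry it further in either direction.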